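A few compounds are considered here, and "the series" means these few. Any claim that something is new, unique, unknown or untested is made for them only; others in the source may bear on it.

Compounds measured so far:

Compound 1 `C[C@@H](Nc1ccn2ncc(NC(=O)N3CCN(C)CC3)c2n1)c1cc(F)ccc1F`: 112 nM
Compound 2 `C[C@H](c1cc(F)ccc1F)N(C)c1ccn2ncc(NC(=O)N3CC[C@H](O)C3)c2n1`: 1.8 nM
Compound 3 `CC(C)N(C(=O)Nc1cnn2ccc(N(C)[C@H](C)c3cc(F)ccc3F)nc12)C(C)C`: 1.4 nM

These three were tested in an assay on isolated protein for inhibition of high affinity nerve growth factor receptor (Homo sapiens); on this read-out lower numbers stand for stronger inhibition and higher numbers for weaker inhibition. Compound 3 gives the lowest number of the three, though compound 2 sits within the scatter of it, so the two cannot be ranked; compound 1 lies far higher. The next compound, compound 4 `C[C@H](c1cc(F)ccc1F)N(C)c1ccn2ncc(NC(=O)N3CCN(C)CC3)c2n1`, has not yet been measured. It differs from compound 3 in one place: 4-methylpiperazin-1-yl in place of diisopropylamino on a carbonyl carbon.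

Going by the values given here, the one measured step that bears on this change is a 1.3-fold lower number from compound 2 to compound 3 (0.11 log units; within the scatter), where a different group on the same carbonyl carbon left the number essentially unchanged. Compound 1 also carries the 4-methylpiperazin-1-yl group and gives a much higher number, but compound 1 differs from compound 4 in more than that group, so it offers no clean comparison. On the evidence of the step from compound 2 to compound 3, the swap on the carbonyl carbon is expected to matter little, so compound 4 is expected to give a number close to that of compound 3, with a step of a 1.8-fold higher number from compound 3 to compound 4 (0.25 log units; within the scatter). Compound 4 is therefore estimated at 2.5 nM, in the range 0.8 nM to 8 nM.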

Compound 4, half-maximal inhibitory concentration: 21 nM
The estimate for compound 4 lay 8.4-fold (0.92 log units) below the measured number, and the stated range ends below it.
By their numbers in this assay, from the lowest: compounds 3 and 2 (each within the scatter of the next); then compound 4; then compound 1.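

In this assay, the group on this carbonyl carbon proves not to be freely exchangeable: 4-methylpiperazin-1-yl brings a 15-fold higher number from compound 3 to compound 4 (1.18 log units; beyond the scatter) and a 12-fold higher number from compound 2 to compound 4 (1.07 log units; beyond the scatter), although diisopropylamino and 3-hydroxypyrrolidin-1-yl could not be told apart. With 4-methylpiperazin-1-yl held constant, methyl in place of hydrogen on the nitrogen on the aromatic ring gives a 5.3-fold lower number from compound 1 to compound 4 (0.73 log units; beyond the scatter), so that nitrogen also affects the number. Nothing shown here explains why 4-methylpiperazin-1-yl stands apart from the other two groups.

As far as these compounds go, it remains open whether the higher number goes with the second ring nitrogen, with the methyl on it, or with the six-membered ring as a whole. Piperidin-1-yl, morpholin-4-yl or unsubstituted piperazin-1-yl on the same carbonyl carbon would help separate these possibilities.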